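The source may report more compounds than this note shows. Statements on the series, on what has been measured and on what is new or still open speak of the compounds shown alone.

Among the compounds with values here, in a functional assay on the whole organism (trachea) for inhibition, with Cavia porcellus as the target (a lower number here means that less compound is needed, a higher number that more compound is needed for the effect), compound 2 (`CN(Cc1cc(C(F)(F)F)cc(C(F)(F)F)c1)C(=O)c1c(-c2ccccc2)c2cccnc2c(=O)n1C`) gives 0.17 mg/kg, the second highest of the three numbers measured so far. Compound 1 (`CN(Cc1cc(C(F)(F)F)cc(C(F)(F)F)c1)C(=O)c1c(-c2ccc(F)cc2)c2cccnc2c(=O)n1C`) gives a lower number, 0.068 mg/kg, and compound 3 (`Cc1ccccc1-c1c(C(=O)N(C)Cc2cc(C(F)(F)F)cc(C(F)(F)F)c2)n(C)c(=O)c2ccccc12`) gives a higher one, 0.81 mg/kg. The next compound to consider is compound 4 (`Cc1ccc(-c2c(C(=O)N(C)Cc3cc(C(F)(F)F)cc(C(F)(F)F)c3)n(C)c(=O)c3ncccc23)cc1`), which changes phenyl to 4-methylphenyl, with methyl in place of hydrogen on an aromatic carbon.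

Within the data shown here, only one measured step bears on this ring: replacing fluoro with hydrogen gives a 2.5-fold higher number from compound 1 to compound 2 (0.40 log units; beyond the scatter). This step is modest but beyond the scatter, and read the other way, it shows that the fluoro compound needs less compound for the effect. Among the measured compounds shown here, compound 3 differs from compound 2 in more than one place, so it offers no clean comparison, and no measured step involves adding methyl alone. The fluoro result is therefore only a rough guide, and a modest move toward a lower number seems likely. The expected step is a 2.1-fold lower number from compound 2 to compound 4 (0.33 log units; beyond the scatter). The estimated value for compound 4 is 0.08 mg/kg, with an expected range from 0.025 mg/kg to 0.25 mg/kg.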

Compound 4, dose for half-maximal effect: 0.11 mg/kg
Beside the measured number, compound 4's estimate is 1.4-fold (0.14 log units) below it, within the range that was stated.
By their numbers in this assay, from the lowest: compounds 1, 4 and 2 (each within the scatter of the next, the first and the last beyond it); then compound 3.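

In this assay, methyl in place of hydrogen on this ring, para to a large group, gives a 1.5-fold lower number from compound 2 to compound 4 (0.19 log units; within the scatter) and so cannot be told apart from hydrogen here. Methyl in place of fluoro at the same carbon gives a 1.6-fold higher number from compound 1 to compound 4 (0.21 log units; within the scatter) and cannot be told apart from fluoro either, even though fluoro and hydrogen themselves differ by a 2.5-fold higher number from compound 1 to compound 2 (0.40 log units; beyond the scatter) in a step beyond the scatter. This position therefore tolerates a one-carbon group, and compound 4 falls among the two compounds already known, while no measurement shown explains these numbers. Going by these compounds, whether a longer chain, a methoxy group, an amine or a carboxylic acid at this carbon would fit the same range remains open. So does whether methyl would behave alike on the other carbons of this ring.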